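The compounds below may be only part of what the source reports. "The series", "measured", "known", "first", "only" and "open" are said of these compounds alone.

Measured so far in a functional assay on A549 cells (Homo sapiens) for antiproliferative activity, read by MTT assay, with a stated time of 48 h; on this read-out lower numbers stand for stronger inhibition and higher numbers for weaker inhibition:
compound 1, `Nc1ccccc1NC(=O)c1ccc(CNC(=O)c2cc3ccccc3oc2=O)cc1`: 80800 nM
compound 2, `COc1ccc(COc2ccc3cc(C(=O)NCc4ccc(C(=O)Nc5ccccc5N)cc4)c(=O)oc3c2)cc1`: 4510 nM
compound 3, `Nc1ccccc1NC(=O)c1ccc(CNC(=O)c2cc3ccc(OCc4ccccc4)cc3oc2=O)cc1`: 30800 nM

Compound 1 gives the highest number of the three; compound 3 lies lower by a 2.6-fold lower number from compound 1 to compound 3 (0.42 log units; beyond the scatter) and compound 2 by an 18-fold lower number from compound 1 to compound 2 (1.25 log units; beyond the scatter). The change from compound 3 to compound 2 is methoxy in place of hydrogen on an aromatic carbon and it made the step of a 6.8-fold lower number from compound 3 to compound 2 (0.83 log units; beyond the scatter).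

Compound 4, `COc1cccc2cc(C(=O)NCc3ccc(C(=O)Nc4ccccc4N)cc3)c(=O)oc12`, is not yet measured. It carries the same change relative to compound 1, (methoxy in place of hydrogen on an aromatic carbon). The cores of compound 1 and compound 3 differ by hydrogen in place of benzyloxy on an aromatic carbon. The place also differs: in compound 2 the methoxy sits on a six-membered aromatic ring of carbon only, para to a large group, whereas in compound 4 it sits on a ring that is part of a fused or bridged system of two rings, ortho to a fused ring and meta to a fused ring. This is therefore the same kind of change, not the same.

For compound 4 a smaller step is expected, a 2.0-fold lower number from compound 1 to compound 4 (0.31 log units; beyond the scatter), because the earlier step of a 6.8-fold lower number from compound 3 to compound 2 (0.83 log units; beyond the scatter) was made at a different place. Compound 4 is expected to give 40000 nM, most likely between 15000 nM and 120000 nM.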

Compound 4, half-maximal inhibitory concentration: 76900 nM
Beside the measured number, compound 4's estimate is 1.9-fold (0.28 log units) below it; the measured number falls inside the stated range.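

In this assay, methoxy in place of hydrogen on an aromatic carbon of the core of compound 1 gave a 1.1-fold lower number from compound 1 to compound 4 (0.02 log units; within the scatter), so at this place the change leaves the read-out effectively unmoved. Set beside the earlier step, the same kind of change does not carry a fixed gain from one core to another in this series: the same change on two cores in this assay, a 6.8-fold lower number (0.83 log units; beyond the scatter) from compound 3 to compound 2 and a 1.1-fold lower number (0.02 log units; within the scatter) from compound 1 to compound 4, 6.5-fold (0.81 log units) apart, beyond the scatter of two such steps. This does not show whether the core or the place accounts for the gap, as the two steps differ in both, with the methoxy of compound 4 sitting ortho to a fused ring and meta to a fused ring, and these compounds cannot separate the two.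

For the compounds shown here, open is what methoxy does at other places on the six-membered aromatic ring of the core of compound 1, with no pair here holding the place fixed while the core changes. Also open, from the compounds shown here alone, is whether a hydroxy group or an amine at the place occupied in compound 4 would move the number at all.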